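A Bromophenyl Swap on an Inactive Amide

This account rests on a few compounds, and the source may have more. Where it says the series, first, only, none or still open, it means among the compounds named here.

Compound 1 `O=C(CN1CCN(c2nnc(Cc3ccccc3)c3ccccc23)CC1)Nc1ccc(Br)cc1`: 2000 nM
Compound 2 `O=C(CN1CCN(c2nnc(Cc3ccccc3)c3ccccc23)CC1)Nc1ccc(F)c(Cl)c1`: "not active" (no number reported)

In a functional assay on A549 cells (Homo sapiens) for cytotoxicity, read by MTT assay, with a stated time of 72 h (on this read-out higher numbers stand for weaker inhibition and lower numbers for stronger inhibition), compound 1 gives 2000 nM, while compound 2 is reported only as "not active" (no number reported), with no single number to place it. Compound 3 `O=C(CN1CCN(c2nnc(Cc3ccccc3)c3ccccc23)CC1)Nc1cccc(Br)c1` has not yet been measured. The change is 3-bromophenyl in place of 3-chloro-4-fluorophenyl on an amide-type nitrogen. No size can be put on this step, since compound 2 has no number. The expected direction is towards stronger, measurable inhibition, resting only on the bromine also carried by compound 1 at 2000 nM. Compound 3 is expected at about 3000 nM, with an estimated range of 800 nM to 12000 nM.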

Compound 3, half-maximal inhibitory concentration: "not active" (no number reported)
No number was reported for compound 3; no gap can be computed for the estimate.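

In this assay compound 2 and compound 3 are both reported only as not active, so no step can be read between them. As far as these compounds go, whether 3-bromophenyl and 3-chloro-4-fluorophenyl differ in this read-out stays open, and no supporting evidence bears on the result.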